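The compounds below may be only part of what the source reports. "The series", "measured", "known", "first", "only" and "open" are said of these compounds alone.

Measured compounds in an assay on CHO cells for inhibition of sphingosine kinase 1 (Homo sapiens), tested at 10 uM; a higher number here means more inhibition at the concentration tested (going by the name of the read-out), a lower number less inhibition:

Compound 1, `CCCCCCCCC#C[C@@H](O)[C@@H](N)CO`: 13.7%
Compound 2, `CCCCCCCCC#CC(=O)[C@@H]1COC(C)(C)N1C(=O)OC(C)(C)C`: 15.2%
Compound 3, `CCCCCCCCCCCCCC#C[C@@H](O)[C@@H](N)CO`: 24.4%

Compound 1 and compound 3 share a core and differ by pentyl in place of hydrogen on a saturated chain carbon, eight bonds along the chain from a triple-bonded carbon. Within the data shown here, the step this makes is a number 10.7 percentage points higher from compound 1 to compound 3 (beyond the scatter), the only change in the set that can be read from two measured points.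

Compound 2 has a different core; the difference between the core of compound 1 and the core of compound 2 is not broken down here. In this assay compound 2 gives a number that is within the usual scatter of that of compound 1 and also within the scatter of that of compound 3, so no order among these three can be read from those pairs.

Compound 4, `CCCCCCCCCCCCCC#CC(=O)[C@@H]1COC(C)(C)N1C(=O)OC(C)(C)C`, is not yet measured. It differs from compound 2 by pentyl in place of hydrogen on a saturated chain carbon, eight bonds along the chain from a triple-bonded carbon, and the place is described in the same words as for the change from compound 1 to compound 3, so this is the same change carried onto the second core. On the first core it was worth a number 10.7 percentage points higher from compound 1 to compound 3 (beyond the scatter). Among the measured compounds shown here, with only that one example, the expectation is that a step of about the same size follows on the core of compound 2, that is a number 10.8 percentage points higher from compound 2 to compound 4 (beyond the scatter), resting on compound 2 at 15.2% as the starting point. The estimate for compound 4 in this assay is therefore 26%, with a range from 14% to 38% expected, the width reflecting that the transfer of a step between cores is supported by one pair only.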

Compound 4, a percentage reported as inhibition, at one concentration (the size of the read-out at that concentration, not a potency): 54.7%
Estimate against measurement, compound 4: 28.7 percentage points below, and the stated range ends below it.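

In this assay, pentyl in place of hydrogen on a saturated chain carbon, eight bonds along the chain from a triple-bonded carbon, gives a number 39.5 percentage points higher from compound 2 to compound 4 (beyond the scatter) on the second core, and the size of the step does not carry over between the two cores: the same change on two cores in this assay, a number 10.7 percentage points higher (beyond the scatter) from compound 1 to compound 3 and a number 39.5 percentage points higher (beyond the scatter) from compound 2 to compound 4, 28.8 percentage points apart, beyond the scatter of two such steps

The change raises the number on both cores, so in these two pairs the direction transfers while the size depends on the core it is placed on. This does not show which part of the difference between the two cores sets the size, since those cores differ in more than one place, and two pairs give no general rule for other cores or for potency, as each number is a reading at one concentration.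

Among these compounds, open is whether the step keeps growing with a longer chain than the one in compound 4, or changes when an amine or a carboxylic acid is placed at the chain end. Also open, on these data alone, is how the same pentyl change behaves on a core that carries the carbonyl of compound 2 together with the free amine of compound 1.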